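Side chain swap on the thiocarbonyl carbon

The source may hold more compounds than are shown below. What is called first, only, known or untested is meant among the compounds shown, and "the series" means these compounds.

Measured so far in a functional assay on HT-29 cells (Homo sapiens) for antiproliferative activity, read by MTT assay, with a stated time of 96 h (a lower number here means a stronger inhibitor, a higher number a weaker inhibitor), as follows
- compound 1 `S=C(N/N=C1\CC2(CCCCC2)Oc2c1ccc1ccccc21)N1CCCCC1` gives 6770 nM
- compound 2 `S=C(N/N=C1\CC2(CCCCC2)Oc2c1ccc1ccccc21)N1CCNCC1` gives 8340 nM

Compound 1 and compound 2 lie within the scatter of each other, so compound 1 holds no distinct rank on these two numbers.

Compound 3 `NCCCCCCC(=S)N/N=C1\CC2(CCCCC2)Oc2c1ccc1ccccc21` has not yet been measured. Against compound 1 it carries this change 6-aminohexyl in place of piperidin-1-yl on a thiocarbonyl carbon with 6-aminohexyl in place of piperidin-1-yl on a thiocarbonyl carbon, and the rest of compound 1 stays the same.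

Within the data shown here, one measured step bears on this place. It is a 1.2-fold higher number from compound 1 to compound 2 (0.09 log units; within the scatter) for piperazin-1-yl in place of piperidin-1-yl, and it stays within the scatter. Among the measured compounds shown here, no measured compound has an open chain here, so this single step offers only limited guidance and the range must stay wide.

The expected step of a 1.4-fold lower number from compound 1 to compound 3 (0.13 log units; within the scatter) in this assay is no larger than the scatter, and its direction is unsettled. Compound 3 is estimated at 5000 nM with an expected range from 1500 nM to 14000 nM in this test.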

Compound 3, half-maximal inhibitory concentration: 3870 nM
For compound 3 the middle estimate is 1.3-fold (0.11 log units) above the measured one; the measured number falls inside the stated range.
By their numbers in this assay, from the lowest: compounds 3, 1 and 2 (each within the scatter of the next, the first and the last beyond it).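

In this assay the thiocarbonyl carbon accepts an open chain as well as a ring: a 1.7-fold lower number from compound 1 to compound 3 (0.24 log units; within the scatter) stays within the scatter, so on these numbers the piperidin-1-yl ring is not required for activity at this place. Among these compounds, the same chain gives the first step in the set that lies beyond the scatter, a 2.2-fold lower number from compound 2 to compound 3 (0.33 log units; beyond the scatter), although this step is only modest and 6-aminohexyl cannot be set apart from piperidin-1-yl. No accompanying data bear on why the numbers fall this way.

The compounds shown do not separate the contribution of the amine from that of the chain: a plain hexyl chain, or a hexyl chain ending in a hydroxyl group or a carboxylic acid, would address that point. Also open, from the compounds shown here alone, is how the number responds to chain length, which a butyl amine or an octyl amine on the thiocarbonyl carbon would test, with the rest of compound 3 kept the same.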